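Methyl on the aromatic nitrogen of compound 3

A few compounds are considered here, and "the series" means these few. Any claim that something is new, unique, unknown or untested is made for them only; others in the source may bear on it.

In an ADME assay on HEK-293T cells (Homo sapiens) for cytotoxicity, read by CCK-8 assay, with a stated time of 24 h (a higher number here means that more compound is tolerated, a lower number that less compound is tolerated), compound 3 (`O=C(CSc1c[nH]c2ccccc12)NCc1ccccc1`) gives > 100000 nM as a limit of the assay, not a number. Compound 1 (`Cn1cc(SCC(=O)NCc2ccc(C(F)(F)F)cc2)c2ccccc21`) gives > 100000 nM as a limit too. Compound 2 (`COc1ccccc1CNC(=O)CSc1cn(C)c2ccccc12`) gives > 100000 nM as a limit too. Compound 3 thus stands at the limit of > 100000 nM in this assay, at which 3 of the 3 values shown sit, and no measured step sizes a change. Compound 4 (`Cn1cc(SCC(=O)NCc2ccccc2)c2ccccc21`) has methyl in place of hydrogen on an aromatic nitrogen. Compound 2 carries that methyl and gives > 100000 nM as a limit. The expected step is a number no higher from compound 3 to compound 4 (the limit leaves the size open) and nothing beyond the scatter is expected in this assay for it. Compound 4 is estimated at 100000 nM with a range of 50000 nM to 200000 nM and is expected to be reported as a limit again.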

Compound 4, half-maximal cytotoxic concentration: 95500 nM
Beside the measured number, compound 4's estimate is 1.0-fold (0.02 log units) above it, within the range that was stated.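

In this assay, within the data shown here, compound 4 gives 95500 nM, the first value that is a number and not a limit. Methyl in place of hydrogen on the aromatic nitrogen gives an at least 1.0-fold lower number from compound 3 to compound 4 (0.01 log units; that floor lies within the scatter), hydrogen in place of methoxy gives an at least 1.0-fold lower number from compound 2 to compound 4 (0.01 log units; that floor lies within the scatter), and hydrogen in place of trifluoromethyl gives an at least 1.0-fold lower number from compound 1 to compound 4 (0.01 log units; that floor lies within the scatter). These are floors only, so none of the three shows a change beyond the scatter, and the other values stay at a limit: the limit of > 100000 nM in this assay, at which 3 of the 4 values shown sit.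

From the compounds shown here alone, the real size of the methyl step stays open. Going by these compounds, whether a longer chain or an amine on that aromatic nitrogen moves the number beyond the scatter also stays open.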